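The source may report more compounds than this note shows. Statements on the series, on what has been measured and on what is new or still open speak of the compounds shown alone.

Measured so far:
Compound 1, `CCCCc1cn(-c2ccc(NC(=O)Nc3ccccc3C)cc2)nn1`: 300 nM
Compound 2, `CC(C)CCc1cn(-c2ccc(NC(=O)Nc3ccccc3F)cc2)nn1`: 120 nM
Compound 3, `CC(C)CCc1cn(-c2ccc(NC(=O)Nc3cccc(F)c3)cc2)nn1`: 200 nM

In an assay for inhibition of ATP-dependent RNA helicase DDX3X (Homo sapiens), read by FRET, with a stated time of 40 min, in the presence of a further agent that is not named here (a lower number here means a stronger inhibitor, a higher number a weaker inhibitor), compound 3 gives 200 nM, the second highest of the three numbers; compound 1 gives 300 nM and compound 2 gives 120 nM, and both of these sit within the scatter of compound 3, so no order among the three can be claimed. Compound 4, `Cc1ccccc1NC(=O)Nc1ccc(-n2cc(CCC(C)C)nn2)cc1`, arises from compound 3 by 2-methylphenyl in place of 3-fluorophenyl on an amide-type nitrogen. Going by the values given here, the one measured step that bears on this is the move a 1.7-fold higher number from compound 2 to compound 3 (0.22 log units; within the scatter), which shows that shifting a small group around this ring left the number essentially unchanged. Compound 1 carries the same 2-methylphenyl group as compound 4 but differs from it in a second place as well, so its value only loosely points the way. The step from compound 3 to compound 4 is therefore expected to be small, no change at the digits printed from compound 3 to compound 4 (within the scatter), with no clear direction beyond the scatter. Compound 4 is estimated at 200 nM in this assay, with a likely range from 70 nM to 550 nM.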

Compound 4, half-maximal inhibitory concentration: 170 nM
Estimate against measurement, compound 4: 1.2-fold (0.07 log units) above; the range from low to high includes it.
By their numbers in this assay, from the lowest: compounds 2, 4, 3 and 1 (each within the scatter of the next, the first and the last beyond it).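

In this assay, 2-methylphenyl in place of 3-fluorophenyl on the amide-type nitrogen gives a 1.2-fold lower number from compound 3 to compound 4 (0.07 log units; within the scatter), so at this position the two groups cannot be told apart, even though both the group and its place on the ring differ. Methyl in place of fluoro on the aromatic carbon gives a 1.4-fold higher number from compound 2 to compound 4 (0.15 log units; within the scatter), so that swap cannot be told apart from the scatter either. Methyl in place of hydrogen on the saturated chain carbon gives a 1.8-fold lower number from compound 1 to compound 4 (0.25 log units; within the scatter), which extends the same reading to this chain branch, and no measurement shown accounts for any of these results.

On these data alone, it remains open how an amine or a carboxylic acid on this phenyl ring would read. A longer chain in place of the present one is equally untested by these compounds.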